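The compounds below may be only part of what the source reports. "The series", "measured", "known", "first", "only" and "open" are said of these compounds alone.

Compound 1 `Cc1ccc(NC(=O)CC(CCN(C)C)c2nnc(CCCC(C)C)n2C2CC2)c(C)c1`: 85%
Compound 2 `Cc1ccc(NC(=O)CC(CCC(=O)N(C)C)c2nnc(CCCC(C)C)n2C2CC2)c(C)c1`: 45%
Compound 3 `Cc1ccc(NC(=O)C[C@H](CCC(=O)O)c2noc(-c3cc(CC(C)C)no3)c2C2CC2)c(Cl)c1`: 54%

In an ADME assay on microsomes from liver (Homo sapiens) for metabolic stability, with a stated time of 60 min (a higher number here means that more of the compound is left, a lower number that less of the compound is left), compound 3 gives 54%, the second highest of the three values: compound 2 sits within the scatter of it, while compound 1 lies beyond the scatter, higher. Compound 4 `Cc1ccc(NC(=O)C[C@H](CCC(=O)O)c2noc(-c3cc(CC(C)(C)C)on3)c2C2CC2)c(Cl)c1` differs from compound 3 by 5-neopentyl-1,2-oxazol-3-yl in place of 3-isobutyl-1,2-oxazol-5-yl on an aromatic carbon. Among the measured compounds shown here, the one measured single-point step, a number 40 percentage points lower from compound 1 to compound 2 (beyond the scatter), concerns a saturated chain group on a different core and says nothing about exchanging one five-membered aromatic ring for another; no measured pair covers this change. The expectation is therefore a step of a number 2 percentage points lower from compound 3 to compound 4 (within the scatter), none beyond the scatter. Compound 4 is estimated at 52%, with a range from 32% to 72%.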

Compound 4, percent of the compound remaining: 84%
Compound 4: middle estimate off by 32 percentage points, on the low side, and the stated range ends below it.
By their numbers in this assay, from the lowest: compounds 2 and 3 (each within the scatter of the next); then compounds 4 and 1 (each within the scatter of the next).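

This position, an aromatic carbon next to the ring oxygen, proves responsive in this assay: 5-neopentyl-1,2-oxazol-3-yl in place of 3-isobutyl-1,2-oxazol-5-yl gives a number 30 percentage points higher from compound 3 to compound 4 (beyond the scatter) with the rest of the molecule unchanged. The step lies beyond the scatter, although both groups hold one five-membered aromatic ring with 2 hetero atoms and differ only slightly in size, at 9 against 10 heavy atoms. Nothing measured here explains the step.

The compounds shown leave open which part of the exchange carries the step, the arrangement of the ring or the neopentyl group, which a 5-isobutyl-1,2-oxazol-3-yl group could separate. Also open, on these data alone, is whether the step holds with an amine in place of the carboxylic acid.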